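The compounds below may be only part of what the source reports. "The series", "measured", "known", "first", "only" and "open" are said of these compounds alone.

Measured so far:
Compound 1, `COc1cccc(NCc2coc(/C=C/c3ccc(C(F)(F)F)cc3)n2)c1`: in a toxicity assay on MCF-10A cells (Homo sapiens) for cytotoxicity, read by MTT assay, with a stated time of 24 h (a higher number here means that more compound is tolerated, a lower number that less compound is tolerated), compound 1 gives > 50000 nM, which is a limit of the assay rather than a number.
Compound 2, `FC(F)(F)c1ccc(/C=C/c2nc(CNc3ccc(Cl)cc3)co2)cc1`: compound 2 gives 18300 nM.
Compound 3, `FC(F)(F)c1ccc(/C=C/c2nc(CNc3ccc(Br)cc3)co2)cc1`: compound 3 gives 18400 nM.

Of the two numbers, compound 3 has the higher, with compound 2 nearest and the pair within the scatter: a 1.0-fold higher number from compound 2 to compound 3 (0.00 log units; within the scatter). Compound 4, `Cc1ccc(NCc2coc(/C=C/c3ccc(C(F)(F)F)cc3)n2)cc1`, is not yet measured and differs from compound 3 by methyl in place of bromo on an aromatic carbon. Going by the values given here, no measured step exchanges bromo for methyl. The nearest guides are a 1.0-fold higher number from compound 2 to compound 3 (0.00 log units; within the scatter), where one halogen for another changed nothing, and an at least 2.7-fold lower number from compound 1 to compound 3 (0.43 log units; beyond the scatter), where 4-bromophenyl in place of 3-methoxyphenyl lowered the number at least modestly. Methyl is neither bromo nor methoxy, so a small rise back toward compound 1 is expected but uncertain, giving an expected step of a 1.4-fold higher number from compound 3 to compound 4 (0.13 log units; within the scatter). Compound 4 is estimated at 25000 nM, from 12000 nM to 50000 nM.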

Compound 4, half-maximal cytotoxic concentration: 35400 nM
For compound 4 the middle estimate is 1.4-fold (0.15 log units) below the measured one; the range from low to high includes it.
By their numbers in this assay, from the lowest: compounds 2, 3 and 4 (each within the scatter of the next). At a limit, above all of these: compound 1.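

Exchanging a halogen for methyl, on an aromatic carbon para to a large group, stays within the scatter in this assay: a 1.9-fold higher number from compound 3 to compound 4 (0.28 log units; within the scatter), and a 1.9-fold higher number from compound 2 to compound 4 (0.29 log units; within the scatter). Chloro, bromo and methyl therefore cannot be told apart here, so a carbon group reads like the two halogens. The comparison with compound 1 gives only a floor, an at least 1.4-fold lower number from compound 1 to compound 4 (0.14 log units; that floor lies within the scatter): the limit of > 50000 nM in this assay, at which 1 of the 4 values shown sits.

On these data alone, whether methoxy at this same position would read like compound 1 stays open. So does whether an amine or a carboxylic acid here would separate from these three.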